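Swapping a sulfonamide for a pyridine at the fused ring

This account rests on a few compounds, and the source may have more. Where it says the series, first, only, none or still open, it means among the compounds named here.

Measured compounds:
Compound 1, `C[C@H](c1ccc(-c2cc(Cl)ccc2-c2nc(=O)o[nH]2)cc1)N(CC1CC1)c1nc2c(C(=O)O)cccc2o1`: 0.000108
Compound 2, `CCCCN(c1nc2c(NS(C)(=O)=O)cccc2o1)[C@H](C)c1ccc(-c2ccccc2-c2nnn[nH]2)cc1`: 0.000203
Compound 3, `CCCCN(c1nc2c(C(=O)O)cccc2o1)[C@H](C)c1ccc(-c2cc(Cl)ccc2-c2nc(=O)o[nH]2)cc1`: 0.000135

In an ADME assay on the whole organism (plasma, Macaca fascicularis) for protein binding, read by LC-MS, using equilibrium dialysis and cassette dosing, with a stated time of 24 h, at a dose of 1 mg/kg by the oral route (a higher number here means a larger unbound share of the compound, a lower number a smaller unbound share), compound 2 gives the highest of the three numbers, but its gaps to compound 3 and to compound 1 are within the scatter, so all three stand together. For the measured compounds named here, the one measured step, a 1.3-fold higher number from compound 1 to compound 3 (0.10 log units; within the scatter), concerns a different part of the shared core and is also within the scatter.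

Compound 4, `CCCCN(c1nc2c(-c3ccccn3)cccc2o1)[C@H](C)c1ccc(-c2ccccc2-c2nnn[nH]2)cc1`, differs from compound 2 by pyridin-2-yl in place of methanesulfonamido on an aromatic carbon. Going by the values given here, no measured step bears on this change, so the expectation rests on compound 2 alone. Compound 4 is expected to show a 1.3-fold lower number from compound 2 to compound 4 (0.10 log units; within the scatter), no step beyond the scatter, with wide uncertainty. The estimate for compound 4 is 0.00016, within 0.00004 to 0.0007.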

Compound 4, unbound fraction: 0.00129
Beside the measured number, compound 4's estimate is 8.1-fold (0.91 log units) below it, outside the stated range (above it).
By their numbers in this assay, from the lowest: compounds 1, 3 and 2 (each within the scatter of the next); then compound 4.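

In this assay, pyridin-2-yl in place of methanesulfonamido on an aromatic carbon gives a 6.4-fold higher number from compound 2 to compound 4 (0.80 log units; beyond the scatter), the only step shown that lies beyond the scatter. For the compounds shown here, this position, ortho to a fused ring, can therefore shift the unbound share, which the earlier compounds, all within the scatter of one another, could not show. No measurement shown accounts for this rise.

Going by these compounds, it remains open whether the ring nitrogen of pyridin-2-yl matters, which a plain phenyl or an amine on this carbon could test. On these data alone, it also remains open whether the same change would give a similar step on other versions of the shared core.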